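The compounds below may be only part of what the source reports. "The series", "measured", "known", "first", "only" and "open" are said of these compounds alone.

Measured so far in a functional assay on cells (Neutrophil, Homo sapiens) for inhibition, read by WST assay, with a stated time of 20 min; a higher number here means a weaker inhibitor, a lower number a stronger inhibitor:
compound 1 `Cc1ccc2c(n1)C(=O)C(Cl)=C(Cl)C2=O` gives 3400 nM
compound 2 `CNC1=C(Cl)C(=O)c2cccnc2C1=O` gives 41100 nM
compound 3 `CNC1=C(SC)C(=O)c2ncccc2C1=O` gives > 200000 nM, which is a limit of the assay and not a number

In this assay compound 2 gives the higher of the two numbers and compound 1 the lower, a gap beyond the usual scatter. Compound 3 sits at the limit of > 200000 nM in this assay, at which 1 of the 3 values shown sits. Compound 4 `CNC1=C(Sc2ccccc2)C(=O)c2cccnc2C1=O` differs from compound 2 by phenylsulfanyl in place of chloro on a double-bonded ring carbon. Within the data shown here, no measured pair shows this kind of exchange. A step toward a weaker inhibitor is nevertheless expected, a 2.9-fold higher number from compound 2 to compound 4 (0.47 log units; beyond the scatter), because compound 3 with its methylsulfanyl group gives only the limit > 200000 nM in place of a number. Compound 4 is therefore estimated at 120000 nM, with a range from 35000 nM to 300000 nM.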

Compound 4, half-maximal inhibitory concentration: 92800 nM
Compound 4: middle estimate off by 1.3-fold (0.11 log units), on the high side; low and high end bracket the measured number.
By their numbers in this assay, from the lowest: compound 1; then compound 2; then compound 4. At a limit, above all of these: compound 3.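

In this assay, phenylsulfanyl in place of chloro on this double-bonded ring carbon gives a 2.3-fold higher number from compound 2 to compound 4 (0.35 log units; beyond the scatter), a modest step toward a weaker inhibitor. The position therefore accepts a much larger group carrying a six-membered aromatic ring, and compound 4 still gives a true number, 92800 nM, and not a limit. Nothing measured here explains the size of this step. Still open, on these data alone, is how an amine, a methoxy group or a carboxylic acid would behave at this position, and whether substituents on the phenyl ring would change the number.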